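Indole hydrazide series: acyl-indole exchange at compound 4

The source may hold more compounds than are shown below. What is called first, only, known or untested is meant among the compounds shown, and "the series" means these compounds.

Measured so far in a functional assay on DU-145 cells (Homo sapiens) for cytotoxicity; a lower number here means a stronger inhibitor, a higher number a weaker inhibitor:
Compound 1 `COc1ccc(Cn2cc(/C=N\NC(=O)c3c[nH]c4ccccc34)c3cc(OC)ccc32)cc1`: 19100 nM
Compound 2 `COc1ccc2c(c1)c(/C=N\NC(=O)c1c[nH]c3ccccc13)cn2Cc1ccc(Cl)cc1`: 50000 nM
Compound 3 `Cn1cc(C(=O)N/N=C\c2cn(Cc3ccc(Cl)cc3)c3cc(F)ccc23)c2ccccc21`: 84200 nM

Compound 3 gives the highest number of the three in this assay; its gap to compound 2 lies within the scatter, its gap to compound 1 beyond it. Going by the values given here, the only single-place step measured is a 2.6-fold higher number from compound 1 to compound 2 (0.42 log units; beyond the scatter), a change on the benzylic ring of the shared core that leaves the acyl side untouched, so it does not bear directly on the next change.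

Compound 4 `O=C(N/N=C\c1cn(Cc2ccc(Cl)cc2)c2cc(F)ccc12)c1c[nH]c2ccc(Br)cc12` differs from compound 3 by 5-bromo-1H-indol-3-yl in place of 1-methyl-1H-indol-3-yl on a carbonyl carbon. Among the compounds with values here, no measured pair isolates this exchange. Compounds 1 and 2, which like compound 4 carry a hydrogen-bond donor on the acyl indole, give lower numbers in this assay than compound 3, but each also differs from compound 3 elsewhere, so this is a loose pointer only. A modest move toward a lower number, a 2.1-fold lower number from compound 3 to compound 4 (0.32 log units; beyond the scatter), is expected rather than a large one. Compound 4 is estimated at 40000 nM, with a likely range from 15000 nM to 100000 nM.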

Compound 4, half-maximal inhibitory concentration: 12500 nM
Estimate against measurement, compound 4: 3.2-fold (0.51 log units) above; measured number below the stated range.
By their numbers in this assay, from the lowest: compounds 4 and 1 (each within the scatter of the next); then compounds 2 and 3 (each within the scatter of the next).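

In this assay the acyl side now proves to be a place where the number responds, with a 6.7-fold lower number from compound 3 to compound 4 (0.83 log units; beyond the scatter) as the first step read there while the rest of the molecule stays fixed. The exchange on the carbonyl carbon brings in a bromine and a hydrogen-bond donor together, so this single step cannot divide the shift between the two. No available data explain the shift.

The compounds shown leave open how the shift divides, a question that 5-bromo-1-methyl-1H-indol-3-yl on the same carbonyl carbon would address directly. Also open, on these data alone, is whether the lower number survives when a nitrile or a carboxylic acid takes the place of the bromine on the acyl indole.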